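The compounds below may be only part of what the source reports. "The series", "measured", "known", "first", "only" and "open" are said of these compounds alone.

Compound 3 `CCCN(Cc1ccccc1C(F)(F)F)C(=O)C1CCN(S(=O)(=O)c2ccc3[nH]ncc3c2)CC1`, compound 2 `CCN(Cc1ccccc1C(F)(F)F)C(=O)C1CCN(S(=O)(=O)c2ccc3cn[nH]c3c2)CC1` and compound 1 `CCN(Cc1ccccc1)C(=O)C1CCN(S(=O)(=O)c2cccnc2)CC1` share one core and were examined in a functional assay on CHO cells for positive allosteric modulation of muscarinic acetylcholine receptor M5 (Homo sapiens), read by calcium flux; on this read-out lower numbers stand for smaller maximal responses and higher numbers for larger maximal responses. There compound 3 gives 94%, while compound 2 gives 92%, a gap that lies within the usual scatter, so the two stand side by side. For compound 1 the result is "not determined" (no result reported), so no number exists for it. Compound 4 `CC(C)(C)CN(Cc1ccccc1C(F)(F)F)C(=O)C1CCN(S(=O)(=O)c2ccc3[nH]ncc3c2)CC1` has not yet been measured. Compared with compound 3 it differs by tert-butyl in place of ethyl on a saturated chain carbon bound to an amide-type nitrogen. Going by the values given here, with only two numbers on the shared core, and those two alike, the step expected a number 6 percentage points lower from compound 3 to compound 4 (within the scatter) is small, at most a slight lowering that stays within the scatter. Compound 4 is therefore expected to give about 88%, with a likely range from 65% to 105%.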

Compound 4, largest response reached (reported as percent of maximum), in percent of the reference or control that the assay uses: 104%
Estimate against measurement, compound 4: 16 percentage points below, within the range that was stated.
By their numbers in this assay, from the lowest: compounds 2, 3 and 4 (each within the scatter of the next, the first and the last beyond it).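

In this assay, putting tert-butyl in place of ethyl on a saturated chain carbon bound to an amide-type nitrogen gives a number 10 percentage points higher from compound 3 to compound 4 (within the scatter) and so leaves the maximal response level. The earlier numbers came only from smaller groups here, and this result shows that a group of 4 heavy atoms instead of 2 still gives a full response. Nothing shown explains why the response holds. On these data alone, whether an amine or a carboxylic acid in place of the tert-butyl would keep this response stays open.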